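The source may report more compounds than this note shows. Statements on the series, on what has been measured and on what is new or still open speak of the compounds shown alone.

Compound 1 `CCCNc1nc(N)nc2c1ncn2/C=C1/CC1(CO)CO` gives > 24000 nM as a limit
Compound 2 `Nc1nc(NC2CCCC2)c2ncn(/C=C3/CC3(CO)CO)c2n1` gives > 20000 nM as a limit

In an ADME assay on Akata cells (Homo sapiens) for cytotoxicity, with a stated time of 7 days (a lower number here means that less compound is tolerated, a higher number that more compound is tolerated), compound 2 stands only at the limit > 20000 nM and has no number. Next comes compound 3 `CCCCCOc1nc(N)nc2c1ncn2/C=C1/CC1(CO)CO` with pentyloxy in place of cyclopentylamino on an aromatic carbon and pentyloxy in place of cyclopentylamino on an aromatic carbon. Within the data shown here, the only measured step, a step that the two limits leave unreadable from compound 1 to compound 2, gives no size to carry over, so no step beyond the scatter is expected in this assay and no direction can be set. For compound 3 the estimate is 18000 nM with an expected range from 5000 nM to 60000 nM. The expected move is an at least 1.1-fold lower number from compound 2 to compound 3 (0.04 log units; that floor lies within the scatter).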

Compound 3, half-maximal cytotoxic concentration: > 20000 nM
Compound 3: only a limit was reported; the forecaster's own chance of this, stated with the estimate: 55%; middle value at least 1.1-fold (0.04 log units) from the limit.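

In this assay compound 3 gives > 20000 nM, which is a limit, so its steps from compound 1 and compound 2 cannot be read. The compounds shown leave open whether pentyloxy, propylamino or cyclopentylamino on the shared core changes the half-maximal cytotoxic concentration at all.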